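The source may report more compounds than this note shows. Statements on the series, on what has been measured and on what is new or still open speak of the compounds shown alone.

Compound 3, whose structure is `CCc1ccc(C2=NN(c3ccc(S(C)(=O)=O)cc3)C(=O)CC2)cc1`, is one of three compounds tested in a functional assay on the whole organism (strain Wistar) for inhibition, with Rattus norvegicus as the target, read by paw edema, with stated times of 30 min and 3 h, at a dose of 0.05 mmol/kg by the oral route; a higher number here means more inhibition at the dose given (going by the name of the read-out), a lower number less inhibition. Compound 3 gives 46.7%. Compound 1, with structure `Cc1ccc(C2=NN(c3ccc(S(C)(=O)=O)cc3)C(=O)CC2)cc1`, gives 46.7%, and compound 2, with structure `COc1ccc(C2=NN(c3ccc(S(C)(=O)=O)cc3)C(=O)CC2)cc1`, gives 46.7%; compound 3 thus stands level with both, and the three values lie within the scatter of one another.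

The unmeasured compound 4 has the structure `CS(=O)(=O)c1ccc(N2N=C(c3ccc(-c4ccccc4)cc3)CCC2=O)cc1`. It differs from compound 3 in one place: phenyl in place of ethyl on an aromatic carbon.

Going by the values given here, none of the measured steps involves a phenyl group, so no step bears directly on this change. The steps that exist all concern small groups on the same aromatic carbon or on the chain attached to it: the step of no change at the digits printed from compound 1 to compound 2 (within the scatter), the step of no change at the digits printed from compound 1 to compound 3 (within the scatter) and the step of no change at the digits printed from compound 2 to compound 3 (within the scatter). All three were within the scatter, so the number in this assay has so far stayed level across these variations. A phenyl is a larger change than any of those, so the expected step of a number 1.7 percentage points lower from compound 3 to compound 4 (within the scatter) is close to none, but with a wider margin of uncertainty than the measured steps would alone imply.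

Compound 4 is therefore estimated to give 45% in this assay, with an expected range from 28% to 62%.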

Compound 4, a percentage reported as inhibition, in the whole organism at one dose (the size of the read-out at that dose, not a potency): 6.6%
The estimate for compound 4 lay 38.4 percentage points above the measured number; the measured number lies below the stated range.
By their numbers in this assay, from the lowest: compound 4; then compounds 1, 2 and 3 (each within the scatter of the next).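

In this assay, going by these compounds alone, this aromatic carbon had so far given level numbers with methyl, methoxy and ethyl, and phenyl is the first group there to move the number beyond the scatter, with a number 40.1 percentage points lower from compound 3 to compound 4 (beyond the scatter). The same large fall appears against the other two groups, with a number 40.1 percentage points lower from compound 2 to compound 4 (beyond the scatter) and a number 40.1 percentage points lower from compound 1 to compound 4 (beyond the scatter), so the level reading across the small groups does not extend to phenyl. Phenyl brings 6 heavy atoms and a six-membered aromatic ring where ethyl has 2 heavy atoms and no ring, while neither group has hydrogen-bond donors, acceptors or a net charge, and no evidence is available to explain the fall.

The compounds shown leave open whether the fall goes with the aromatic ring itself or with the number of atoms in the group, a question that a hexyl chain or a saturated cyclohexyl ring on the same aromatic carbon would address. They also leave open whether a phenyl carrying an amine or a carboxylic acid would stay this low, and, with a single dose, how the compounds compare in potency.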